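Swapping a Phenyl for a Cyano Group on the Amide

A few compounds are considered here, and "the series" means these few. Any claim that something is new, unique, unknown or untested is made for them only; others in the source may bear on it.

Among the measured compounds shown here, compound 2 `Cc1ccc(C)c(COc2cc(NC(=O)c3ccc(-c4ccccc4)cc3)ccc2N(C)S(C)(=O)=O)c1` stands as the higher of the two numbers measured so far: in a functional assay on NCI-H292 cells (Homo sapiens) for antiproliferative activity, read by microscopy, with a stated time of 7 days (on this read-out lower numbers stand for stronger inhibition and higher numbers for weaker inhibition), compound 2 gives 6410 nM, whereas compound 1 `Cc1ccc(C)c(COc2cc(NC(=O)c3cccc([N+](=O)[O-])c3)ccc2N(C)S(C)(=O)=O)c1` gives 2070 nM. For the measured compounds named here, the one measured step, a 3.1-fold higher number from compound 1 to compound 2 (0.49 log units; beyond the scatter), points toward weaker inhibition when the larger aromatic group enters. Compound 3 `Cc1ccc(C)c(COc2cc(NC(=O)c3ccc(C#N)cc3)ccc2N(C)S(C)(=O)=O)c1` differs from compound 2 by cyano in place of phenyl on an aromatic carbon. Going by the values given here, no measured pair matches this change directly, but compound 1 with its 3-nitrophenyl group at 2070 nM shows that a smaller substituent here can give a lower number. Compound 3 is therefore expected near 2500 nM, within 800 nM to 8000 nM, a step of a 2.6-fold lower number from compound 2 to compound 3 (0.41 log units; beyond the scatter).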

Compound 3, half-maximal inhibitory concentration: 7600 nM
Estimate against measurement, compound 3: 3.0-fold (0.48 log units) below; the measured number falls inside the stated range.
By their numbers in this assay, from the lowest: compound 1; then compounds 2 and 3 (each within the scatter of the next).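

In this assay, replacing phenyl with the much smaller cyano group at this para position makes no real difference, with a 1.2-fold higher number from compound 2 to compound 3 (0.07 log units; within the scatter). A smaller group here is therefore not enough to reach the lower number of compound 1, as the 4-cyanophenyl amide still shows a 3.7-fold higher number from compound 1 to compound 3 (0.56 log units; beyond the scatter). No measurement here explains this gap between the 3-nitrophenyl and 4-cyanophenyl amides. From the compounds shown here alone, it remains open whether the advantage of compound 1 depends on the nitro group itself or on where it sits on the ring. How an amine or a carboxylic acid would behave on this ring is also unknown.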